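A few compounds are considered here, and "the series" means these few. Any claim that something is new, unique, unknown or untested is made for them only; others in the source may bear on it.

Compound 1 `NC1=NC2(CCOCC2)N(OCCCOc2ccccc2)C(N)=N1` carries a plain phenyl on the oxygen of the propyl chain. In an assay on isolated protein for inhibition of Dihydrofolate reductase (Homo sapiens), read by spectrophotometry, using NADPH, with stated times of 5 s and 6 min, tested at 5 uM (a higher number here means a stronger effect of the compound at the concentration tested, a lower number a weaker effect), compound 1 gives > 90%, which is a limit of the assay and not a number. Compound 3 `NC1=NC2(CCOCC2)N(OCCCOc2ccc(Cl)cc2Cl)C(N)=N1` also reaches that limit, giving > 90% in this assay. Compound 2 `NC1=NC2(CCOCC2)N(OCCCOc2cccc(Cl)c2Cl)C(N)=N1` gives 81.7% in this assay. Among the compounds with values here, the measured steps are a number at least 8.3 percentage points lower from compound 1 to compound 2 (that floor lies within the scatter), a step that the two limits leave unreadable from compound 1 to compound 3 and a number at least 8.3 percentage points higher from compound 2 to compound 3 (that floor lies within the scatter); two of them rest on a limit, as the limit of > 90% in this assay, at which 2 of the 3 values shown sit, states, so only the step to compound 2 has a readable floor, and even that floor lies within the scatter.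

Compound 4 `NC1=NC2(CCOCC2)N(OCCCOc2ccc(Cl)c(Cl)c2)C(N)=N1` differs from compound 1 by 3,4-dichlorophenyl in place of phenyl on an oxygen on a saturated carbon. The two dichlorophenyl analogues already measured bear on it: one sits at the limit, the other stays within the scatter of that limit. Compound 4 is therefore expected to show no step beyond the scatter, a number at least 2 percentage points lower from compound 1 to compound 4 (that floor lies within the scatter), and its inhibition is estimated at 88% (range 76% to 95%), with a fair chance that only a limit is reported.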

Compound 4, a percentage reported as inhibition, at one concentration (the size of the read-out at that concentration, not a potency): > 90%
Compound 4: only a limit was reported (the forecaster's own chance of this, stated with the estimate: 45%); middle value at least 2 percentage points from the limit.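

Compound 4 shows that a third dichlorophenyl pattern, 3,4-dichlorophenyl on an oxygen on a saturated carbon, also leaves inhibition at a limit of the assay in this assay, so two of the three dichlorophenyl analogues shown now sit there with plain phenyl. Within the data shown here, the one readable step is a number at least 8.3 percentage points higher from compound 2 to compound 4 (that floor lies within the scatter), so even this change does not clearly separate compound 4 from the 2,3-dichlorophenyl analogue. The steps to compound 4 from compound 1 and from compound 3 cannot be read because both ends of each rest on the same limit: the limit of > 90% in this assay, at which 3 of the 4 values shown sit.

On these data alone, whether any dichlorophenyl pattern truly differs from plain phenyl therefore stays open. So does how a phenyl bearing an amine or a carboxylic acid, or a longer chain, would fare in this assay.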